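This account rests on a few compounds, and the source may have more. Where it says the series, first, only, none or still open, it means among the compounds named here.

Among the measured compounds shown here, in a functional assay on the whole organism (strain Wistar) for inhibition, with Rattus norvegicus as the target, read by paw edema, with a stated time of 3 h, at a dose of 10 mg/kg by the intraperitoneal route (a lower number here means less inhibition, a higher number more inhibition at the dose given (going by the name of the read-out)), compound 2 `CNc1ncccc1C(=O)N/N=C/c1ccccc1` gives 22.7%, the lowest of the three numbers measured so far. Its nearest neighbour is compound 3 `CNc1ncccc1C(=O)N/N=C/c1cccc(Cl)c1`, which gives 39.6% in this assay, and the furthest is compound 1 `O=C(N/N=C/c1ccc(O)cc1)c1cccnc1Nc1cccc(C(F)(F)F)c1`, which gives 59.5% in this assay. Compound 4 `CNc1ncccc1C(=O)N/N=C/c1ccc(Cl)cc1` has not yet been measured; it differs from compound 2 by chloro in place of hydrogen on an aromatic carbon. For the measured compounds named here, the one measured step that bears on this is a number 16.9 percentage points higher from compound 2 to compound 3 (beyond the scatter), a modest rise beyond the scatter from chloro in place of hydrogen on an aromatic carbon. Going by the values given here, compound 1 has a different core, so its number offers no direct step. A rise of similar size is therefore expected, a number 17.3 percentage points higher from compound 2 to compound 4 (beyond the scatter). Compound 4 is estimated at 40%, within a range of 25% to 55%.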

Compound 4, a percentage reported as inhibition, in the whole organism at one dose (the size of the read-out at that dose, not a potency): 22.4%
The estimate for compound 4 lay 17.6 percentage points above the measured number, outside the stated range (below it).
By their numbers in this assay, from the lowest: compounds 4 and 2 (each within the scatter of the next); then compound 3; then compound 1.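

In this assay chloro in place of hydrogen, para to a large group, gives a number 0.3 percentage points lower from compound 2 to compound 4 (within the scatter) whereas the same replacement elsewhere on the ring gives a number 16.9 percentage points higher from compound 2 to compound 3 (beyond the scatter) in this series. The earlier compounds shown here could not show that the outcome of this change depends on where on the ring the chloro sits. Nothing measured here accounts for that difference.

The compounds shown leave open whether another group at this para place, such as methoxy, an amine or a carboxylic acid, would differ from hydrogen as chloro does not.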